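Compound 3 loses its methoxy group

This account rests on a few compounds, and the source may have more. Where it says the series, first, only, none or still open, it means among the compounds named here.

Measured so far in a functional assay on A549 cells (Homo sapiens) for inhibition, read by MTT assay, with a stated time of 48 h (on this read-out lower numbers stand for stronger inhibition and higher numbers for weaker inhibition), and still open:
- compound 1 `COc1cc(/C=N/Nc2nc(-c3ccc(C(F)(F)F)cc3)cs2)c(Br)c(Br)c1OC` (17600 nM)
- compound 2 `Fc1ccc(/C=N/Nc2nc(-c3ccc(F)c(F)c3)cs2)cc1F` (8490 nM)
- compound 3 `COc1ccccc1-c1csc(N/N=C/c2ccc(F)c(F)c2)n1` (61300 nM)
- compound 4 `Fc1ccc(/C=N/Nc2nc(-c3ccccc3)cs2)cc1F` (not yet measured)

Compound 3 has the highest number of the three (61300 nM), with compound 1 nearest and compound 2 furthest. The change to compound 4 is hydrogen in place of methoxy on an aromatic carbon, hydrogen in place of methoxy, ortho to a large group. Going by the values given here, only one measured step bears on it: a 7.2-fold higher number from compound 2 to compound 3 (0.86 log units; beyond the scatter), with 2-methoxyphenyl in place of 3,4-difluorophenyl. That step also adds the methoxy group, but it removes two fluorines as well, so it is only a partial guide. A modest fall in the number is expected in this assay, smaller than that measured step. The estimated step is a 2.6-fold lower number from compound 3 to compound 4 (0.41 log units; beyond the scatter) and would be modest. Compound 4 is estimated at 24000 nM (expected range 8000 nM to 60000 nM).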

Compound 4, half-maximal inhibitory concentration: 91400 nM
For compound 4 the middle estimate is 3.8-fold (0.58 log units) below the measured one; the whole stated range lies below it.
By their numbers in this assay, from the lowest: compound 2; then compound 1; then compounds 3 and 4 (each within the scatter of the next).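

In this assay, hydrogen in place of methoxy gives a 1.5-fold higher number from compound 3 to compound 4 (0.17 log units; within the scatter), so the methoxy group makes no readable difference at this position on the phenyl ring. With phenyl in place of 3,4-difluorophenyl, the series shows an 11-fold higher number from compound 2 to compound 4 (1.03 log units; beyond the scatter), which ties the gap to the loss of 3,4-difluorophenyl, not to the arrival of methoxy. No measurement bearing on the reason for this is available. Open, as far as these compounds go, is whether an amine or a hydroxyl group at this position would depart from this level, and whether a single fluorine on the phenyl ring would move the number toward that of compound 2.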